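The source may hold more compounds than are shown below. What is called first, only, known or untested is meant among the compounds shown, and "the series" means these compounds.

Compound 1 `CC(C)[C@@H](NC(=O)CC1CC1)C(=O)N1CCC(c2ccc(Cl)cc2)CC1` has an amide built from a cyclopropyl-bearing acid on one side of a shared core. In an assay on THP-1 cells for displacement of a labelled ligand from C-C chemokine receptor type 1 (Homo sapiens) (on this read-out higher numbers stand for weaker inhibition and lower numbers for stronger inhibition), compound 1 gives 46 nM. Two other compounds share the same core: compound 2 `CC[C@@H](C)[C@@H](NC(=O)CC(C)C)C(=O)N1CCC(c2ccc(Cl)cc2)CC1` gives 34 nM in this assay, and compound 3 `CC(C)C(NC(=O)c1ccc2ccccc2c1)C(=O)N1CCC(c2ccc(Cl)cc2)CC1` gives 80 nM. The three numbers all lie within the usual scatter of one another, so none of them can be said to stand apart from the rest, and no single change between them has been worked out; only the values themselves are known.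

Compound 4 `CC(C)[C@@H](NC(=O)CCCc1ccccc1)C(=O)N1CCC(c2ccc(Cl)cc2)CC1` is not yet measured. It differs from compound 1 in one place: phenethyl in place of cyclopropyl on a saturated chain carbon bound to a carbonyl carbon. Since the three known compounds with different amide-side groups all give similar numbers, the new group is expected to bring no step beyond the scatter, with the estimated step from compound 1 to compound 4 being a 1.2-fold lower number from compound 1 to compound 4 (0.06 log units; within the scatter). Compound 4 is therefore estimated at 40 nM in this assay, within a range from 15 nM to 120 nM.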

Compound 4, half-maximal inhibitory concentration: 95 nM
Estimate against measurement, compound 4: 2.4-fold (0.38 log units) below, within the range that was stated.
By their numbers in this assay, from the lowest: compounds 2, 1, 3 and 4 (each within the scatter of the next, the first and the last beyond it).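

In this assay, for the compounds shown here, phenethyl in place of cyclopropyl on a saturated chain carbon bound to a carbonyl carbon gives a 2.1-fold higher number from compound 1 to compound 4 (0.31 log units; beyond the scatter) and is the first step here that can be tied to a single change. It shows that this position responds to the group placed there: the larger group, with 8 heavy atoms against 3 and a six-membered aromatic ring instead of a three-membered ring, brings modestly weaker inhibition, not a collapse. No measurement shown here accounts for this step.

Still open, on these data alone, is whether the aromatic ring or the greater size of the group matters more, a question that one change alone cannot settle. A saturated cyclohexylethyl group would compare the two rings at the same chain length, while an amine or a carboxylic acid at the chain end would test a quite different kind of group.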